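One Ester Side Chain, Rearranged

The source may hold more compounds than are shown below. What is called first, only, known or untested is meant among the compounds shown, and "the series" means these compounds.

Compound 1 `COc1cccc2cc(-c3ccccc3)c(O)nc12`: 10000 nM
Compound 2 `CCOC(=O)Cn1c(=O)c(-c2ccc(OC)cc2)cc2c(OC)cc(OC)cc21`: 10000 nM

In a functional assay on A 172 cells (Homo sapiens) for cytotoxicity, read by colorimetric assay and MTT assay (a lower number here means a stronger inhibitor, a higher number a weaker inhibitor), compound 2 stands level with compound 1, with no difference at the digits shown. Compound 3 `COC(=O)CCn1c(=O)c(-c2ccc(OC)cc2)cc2c(OC)cc(OC)cc21` keeps the core of compound 2 and differs only in its ester side chain: (methoxycarbonyl)methyl in place of ethoxycarbonyl on a saturated chain carbon bound to an aromatic nitrogen. Cut one bond further out, the same difference reads (ethoxycarbonyl)methyl to 2-(methoxycarbonyl)ethyl. Going by the values given here, no measured pair of compounds shows the effect of a change of this kind, so the closest guide is compound 2 at 10000 nM. The expected result is no change at the digits printed from compound 2 to compound 3 (within the scatter), which means no expected shift beyond the scatter in this assay. Compound 3 is expected at 10000 nM, with an estimated range from 4000 nM to 20000 nM.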

Compound 3, half-maximal inhibitory concentration: 10000 nM
For compound 3 middle estimate and measured number coincide at the digits printed; the range from low to high includes it.
By their numbers in this assay, from the lowest: compounds 1, 2 and 3 (each within the scatter of the next).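

Going by these compounds alone, until this result no two compounds differing in one place could be compared, so this is the first reading on this ester side chain. In this assay the rearrangement of the same atoms, from (ethoxycarbonyl)methyl to 2-(methoxycarbonyl)ethyl, gives no change at the digits printed from compound 2 to compound 3 (within the scatter), so this change does not separate the two compounds. No supporting data offer an explanation for this result.

Within the data shown here, with only this one step, it remains unclear whether any change at this position can shift the value from the 10000 nM of compound 3. A carboxylic acid in place of the ester, an amine, or a longer chain at this position might read differently, and the compounds shown do not settle that.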